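Two acids, one close pair of lipophilicity values

A few compounds are considered here, and "the series" means these few. Any claim that something is new, unique, unknown or untested is made for them only; others in the source may bear on it.

Measured in a physicochemical assay for lipophilicity, at pH 7.4; on this read-out higher numbers stand for higher lipophilicity and lower numbers for lower lipophilicity:
compound 1 `CC(C(=O)O)c1nn(Cc2cn3cc(OCC4CC4)c(Cl)cc3n2)c2ccccc2c1=O`: 2.44
compound 2 `O=C(O)C1(c2nn(Cc3cn4cc(OCC5CC5)c(Cl)cc4n3)c3ccccc3c2=O)CC1`: 2.46

Within the data shown here, with only two numbers in hand, compound 2 at 2.46 cannot be told apart from compound 1 at 2.44. The next compound to be read is compound 3 `C[C@H](C(=O)O)c1nn(Cc2cn3cc(OCC4CC4)c(Cl)cc3n2)c2ccccc2c1=O`. The change from compound 2 is 1-carboxyethyl in place of 1-carboxycyclopropyl on an aromatic carbon, next to the ring nitrogen, with the rest of the structure unchanged.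

Among the measured compounds shown here, one measured step bears on this exchange, since it joins the same two groups in the opposite direction: a number 0.02 log units higher from compound 1 to compound 2 (within the scatter). That step is small and gives no reason to look for a larger one here. For the measured compounds named here, no measured step tests the defined stereocentre that compound 3 carries, so that feature adds uncertainty rather than a direction. No shift beyond the scatter is therefore expected in this assay. For compound 3 the estimated value is 2.44, with an expected range of 2.2 to 2.7. This estimate amounts to an expected a number 0.02 log units lower from compound 2 to compound 3 (within the scatter).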

Compound 3, distribution coefficient: 2.39
The estimate for compound 3 lay 0.05 log units above the measured number, and the stated range covers the measured number.
By their numbers in this assay, from the lowest: compounds 3, 1 and 2 (each within the scatter of the next).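

In this assay the exchange of 1-carboxycyclopropyl for 1-carboxyethyl on this aromatic carbon, now with a defined stereocentre on the chain, gives a number 0.07 log units lower from compound 2 to compound 3 (within the scatter) and so does not separate the two groups in this read-out. Among these compounds, the stereo comparison, which the earlier compounds could not offer, gives a number 0.05 log units lower from compound 1 to compound 3 (within the scatter) as its whole reading, and a single difference stands behind it: the fact that one of compounds 1 and 3 is drawn with a defined configuration and the other without, at the place where they differ. Neither removing the three-membered ring nor drawing the S configuration at the saturated chain carbon takes the number outside the scatter, so compounds 1, 2 and 3 remain a single group in this assay for the changes shown at this position.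

From the compounds shown here alone, all three compounds carry a carboxylic acid on the group at this position, so it remains open whether an amide or a primary alcohol in its place would stay as close in this assay as these three do. Also open, going by these compounds, are the R configuration at the chain carbon and whether this closeness would persist with a different substituent on the shared core.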